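The source may hold more compounds than are shown below. What is called first, only, known or untested is meant among the compounds shown, and "the series" means these compounds.

In a functional assay on T47D cells (Homo sapiens) for inhibition, read by CCK-8 assay, with a stated time of 72 h, tested at 10 uM (on this read-out lower numbers stand for less inhibition of growth and higher numbers for more inhibition of growth at the one concentration tested), three compounds sharing one core have been measured. Compound 1 (`CN(C)C(=O)c1cc2cnc(Nc3ccc(NC(=O)C4(C(=O)Nc5ccc(Cl)cc5)CC4)cc3)nc2n1C1CCCC1`) gives 95%, compound 2 (`CN(C)C(=O)c1cc2cnc(Nc3ccc(NC(=O)C4(C(=O)Nc5ccccc5F)CC4)cc3)nc2n1C1CCCC1`) gives 97.8%, and compound 3 (`Cc1ccc(NC(=O)C2(C(=O)Nc3ccc(Nc4ncc5cc(C(=O)N(C)C)n(C6CCCC6)c5n4)cc3)CC2)cc1`) gives 99.6%. Compound 3 therefore stands level with the other two, as the steps to it show: a number 4.6 percentage points higher from compound 1 to compound 3 (within the scatter) and a number 1.8 percentage points higher from compound 2 to compound 3 (within the scatter).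

Compound 4 (`COc1cccc(NC(=O)C2(C(=O)Nc3ccc(Nc4ncc5cc(C(=O)N(C)C)n(C6CCCC6)c5n4)cc3)CC2)c1`) has 3-methoxyphenyl in place of 4-methylphenyl on an amide-type nitrogen. For the measured compounds named here, no compound with 3-methoxyphenyl has been measured, so the evidence is indirect. Going by the values given here, the steps that bear on this change are those that exchange the group on this same nitrogen: the two above and a number 2.8 percentage points higher from compound 1 to compound 2 (within the scatter). All of them stayed within the scatter, whichever group came in.

On that basis, no step beyond the scatter is expected in this assay, and no direction can be claimed. The expected step is small: a number 2.6 percentage points lower from compound 3 to compound 4 (within the scatter). For compound 4 the estimated value is 97%, with an expected range from 88% to 101%.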

Compound 4, percent growth inhibition at one concentration: 93.5%
Compound 4: middle estimate off by 3.5 percentage points, on the high side; the measured number falls inside the stated range.
By their numbers in this assay, from the lowest: compounds 4, 1, 2 and 3 (each within the scatter of the next).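

In this assay, for the compounds shown here, 3-methoxyphenyl on this amide-type nitrogen, the only group here that carries an oxygen and a hydrogen-bond acceptor, stays within the scatter of 4-methylphenyl (a number 6.1 percentage points lower from compound 3 to compound 4 (within the scatter)), of 2-fluorophenyl (a number 4.3 percentage points lower from compound 2 to compound 4 (within the scatter)) and of 4-chlorophenyl (a number 1.5 percentage points lower from compound 1 to compound 4 (within the scatter)). The four aryl groups therefore cannot be told apart on this read-out at the one concentration tested, and the oxygen-bearing group fits the same picture as the other three. Nothing available offers a reason for these numbers.

As far as these compounds go, it remains open whether this nitrogen would keep such numbers with a group that is not aromatic, such as cyclohexyl, or with a phenyl ring bearing an amine or a carboxylic acid. From the compounds shown here alone, whether the four groups would separate at lower concentrations also stays open.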